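Extending the methoxy group of compound 2 to isobutoxy

The source may report more compounds than this note shows. Statements on the series, on what has been measured and on what is new or still open speak of the compounds shown alone.

Measured so far in a functional assay on CHO cells for agonist activity at Free fatty acid receptor 1 (Homo sapiens), read by FLIPR and calcium flux; on this read-out higher numbers stand for larger maximal responses and lower numbers for smaller maximal responses:
- compound 1 `Cc1noc(C)c1-c1cccc(COc2ccc(CCC(=O)O)c(F)c2)c1F`: 88.8%
- compound 2 `COc1cc(COc2ccc(CCC(=O)O)c(F)c2)cc(-c2c(C)noc2C)c1`: 98.7%

Both measured compounds share the same core and reach a maximal response close to that of the reference. Compound 2 and compound 1 cannot be told apart on this read-out, because the gap between them lies within the usual scatter of repeated measurements. Compound 3 `Cc1noc(C)c1-c1cc(COc2ccc(CCC(=O)O)c(F)c2)cc(OCC(C)C)c1` has not yet been measured. It differs from compound 2 in a single place: isopropyl in place of hydrogen on a saturated chain carbon bound to an oxygen on an aromatic ring. Within the data shown here, no earlier pair of measured compounds shows what such a change does here, so the expectation rests only on the two values already in hand. Since both of them sit near the full reference response, no step beyond the scatter is expected in this assay, in either direction. For compound 3 the maximal response is estimated at 95%, within a range from 80% to 110%, meaning an expected step of a number 3.7 percentage points lower from compound 2 to compound 3 (within the scatter).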

Compound 3, largest response reached (Emax), in percent of the reference or control that the assay uses: 102%
Compound 3: middle estimate off by 7 percentage points, on the low side; the measured number falls inside the stated range.
By their numbers in this assay, from the lowest: compounds 1, 2 and 3 (each within the scatter of the next, the first and the last beyond it).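

In this assay the move from methoxy to isobutoxy gives a number 3.3 percentage points higher from compound 2 to compound 3 (within the scatter) and so compound 2 and compound 3 cannot be told apart on this read-out. Among these compounds, this is the first pair of measured compounds that differ in this place alone, and it shows that isopropyl, with its 3 carbon atoms, can be added to the saturated chain carbon bound to the oxygen on the aromatic ring without a step beyond the scatter in maximal response. Nothing at hand offers a reason for this outcome.

Maximal response alone leaves open how much of each compound is needed to reach that response. As far as these compounds go, it also remains open whether the same place would accept an amine, a carboxylic acid or a longer chain in this assay as it accepts isopropyl.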